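The source may hold more compounds than are shown below. What is called first, only, known or untested is meant among the compounds shown, and "the series" means these compounds.

Compound 1 `OC(CCn1cc(-c2ccc(-c3ccccc3)cc2)nn1)CN1CCN(c2cccc(Cl)c2Cl)CC1` is the starting point of this account. In an assay on HEK293 cells for displacement of a labelled ligand from D(4) dopamine receptor (Homo sapiens), read by scintillation counting, with a stated time of 1 h (on this read-out lower numbers stand for stronger inhibition and higher numbers for weaker inhibition), compound 1 gives only a limit, > 7000 nM, and no single number. Compound 3 `OC(CCn1cc(-c2ccc3ccccc3c2)nn1)CN1CCN(c2cccc(Cl)c2Cl)CC1` likewise gives only a limit in this assay, > 20000 nM. Compound 2 `OC(CCn1cc(-c2ccc3ncccc3c2)nn1)CN1CCN(c2cccc(Cl)c2Cl)CC1` has no result in this assay, "not determined" (no result reported). Among the values shown, compound 1 therefore stands at one limit, described by the limit of > 7000 nM in this assay, at which 1 of the 3 values shown sits, while compound 3 sits at the other, described by the limit of > 20000 nM in this assay, at which 1 of the 3 values shown sits. Within the data shown here, the one step between measured compounds that differ in a single place, a step that the two limits leave unreadable from compound 1 to compound 3, cannot be read because both ends are limits.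

Compound 4 `Clc1cccc(N2CCN(CCCCn3cc(-c4ccc(-c5ccccc5)cc4)nn3)CC2)c1Cl` differs from compound 1 in one place: hydrogen in place of hydroxy on a saturated chain carbon bound to two saturated chain carbons. No measured step touches this change, and the only step shown is unreadable, so no size or direction can be taken from the measured compounds. Compound 4 is therefore expected to stay near the limit seen for compound 1, with the step that the limit leaves unreadable from compound 1 to compound 4 estimated as no change beyond the scatter. Compound 4 is estimated at 8000 nM, within the range 2000 nM to 30000 nM.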

Compound 4, inhibition constant: > 10000 nM
Compound 4 was reported as a limit; the forecaster's own chance of this, stated with the estimate: 70%; middle value at least 1.2-fold (0.09 log units) from the limit.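

Compound 1 and compound 4 both give only a limit in this assay, and the step between them cannot be read. The compounds shown leave open whether hydrogen in place of hydroxy on that saturated chain carbon changes the result in this assay at all.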